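A few compounds are considered here, and "the series" means these few. Any claim that something is new, unique, unknown or untested is made for them only; others in the source may bear on it.

Compound 1 `COc1ccnc(-c2csc(Nc3ccc(Cl)cn3)n2)c1` and compound 2 `COc1ccnc(-c2nc(Nc3ccc(Cl)cn3)sc2Cl)c1` share one core, while compound 3 `Clc1ccc(Nc2nc(-c3cccnn3)cs2)nc1` is built on another. In a physicochemical assay for solubility, in phosphate buffer, with a stated time of 2 h, at pH 7.4 (a lower number here means a less soluble compound, a higher number a more soluble compound), compound 1 gives a value that is a limit of the assay, < 10000 nM. Compound 2 in this assay also gives a limit, < 10000 nM. Compound 3 in this assay gives 20000 nM. Compound 2 arises from compound 1 by chloro in place of hydrogen on an aromatic carbon; the step that the two limits leave unreadable from compound 1 to compound 2 has no readable size because of the limit of < 10000 nM in this assay, at which 2 of the 3 values shown sit. How the core of compound 3 differs from that of compound 1 is not broken down here.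

Compound 4 `Clc1ccc(Nc2nc(-c3cccnn3)c(Cl)s2)nc1` has not yet been measured in this assay. It arises from compound 3 by the same kind of change, (chloro in place of hydrogen on an aromatic carbon); around the place, the chloro in compound 4 sits next to the ring atom that bears a pyridazin-3-yl group (6 heavy atoms), whereas in compound 2 it sits next to the ring atom that bears a group of 8 heavy atoms. The measured step offers no size to lean on. Compound 4 is expected to give 8000 nM in this assay. Compound 4 is estimated to fall between 3000 nM and 25000 nM. The step from compound 3 to compound 4 is expected to be a 2.5-fold lower number from compound 3 to compound 4 (0.40 log units; beyond the scatter), resting only on compound 3 at 20000 nM.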

Compound 4, solubility: < 10000 nM
Compound 4 was reported as a limit; the forecaster's own chance of this, stated with the estimate: 55%; the middle value is on the limit's open side.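

On the core of compound 3, chloro in place of hydrogen on an aromatic carbon gives an at least 2.0-fold lower number from compound 3 to compound 4 (0.30 log units; that floor lies within the scatter) in this assay and no more exact size can be stated. In this assay compound 4 gives < 10000 nM which is a limit of the assay and not a number. The step from compound 1 to compound 2 cannot be read, so the result does not show whether the change has a similar size on both cores, because the values of both compounds stand at a limit: the limit of < 10000 nM in this assay, at which 3 of the 4 values shown sit.

The compounds shown leave open how an amine or a carboxylic acid, in place of chloro on that aromatic carbon of the five-membered aromatic ring, would read in this assay on either core. They also leave open whether any such group on the core of compound 1 would give a number rather than a limit.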